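This account rests on a few compounds, and the source may have more. Where it says the series, first, only, none or still open, it means among the compounds named here.

Compound 1 `Cc1ccsc1/C(=C/CCCCC(=O)O)c1cccnc1` gives the lowest of the two numbers measured in an assay (Equus caballus) for inhibition of Thromboxane-A synthase (Homo sapiens), using microsomes (a lower number here means a stronger inhibitor, a higher number a weaker inhibitor), with compound 1 at 29 nM, while compound 2 `COC(=O)CCCC/C=C(\c1ccccc1)c1cccnc1` gives 100 nM, a gap that lies beyond the usual scatter. Compound 3 `C/C(=C/CCCCC(=O)O)c1cccnc1` differs from compound 1 by methyl in place of 3-methylthiophen-2-yl on a double-bonded chain carbon bound to an aromatic carbon and a double-bonded chain carbon. Going by the values given here, no measured pair shows this change, so its size is unknown; as the change removes a whole ring and leaves only a small group, the expected step from compound 1 to compound 3 in this assay is a 5.2-fold higher number from compound 1 to compound 3 (0.71 log units; beyond the scatter), toward weaker inhibition. Compound 3 is therefore estimated at 150 nM, within 40 nM to 600 nM.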

Compound 3, half-maximal inhibitory concentration: 71 nM
Compound 3: middle estimate off by 2.1-fold (0.32 log units), on the high side; the measured number falls inside the stated range.
By their numbers in this assay, from the lowest: compound 1; then compounds 3 and 2 (each within the scatter of the next).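

Replacing 3-methylthiophen-2-yl with methyl on this double-bonded chain carbon gives a 2.4-fold higher number from compound 1 to compound 3 (0.39 log units; beyond the scatter) in this assay. The ring therefore adds to inhibition, but the step is modest, so the aromatic ring at this position is not essential: compound 3 remains an inhibitor with only a methyl there. Still open, going by these compounds, is how inhibition changes with groups of other sizes at this carbon, such as ethyl, isopropyl or cyclopropyl, and whether any of them matches the ring. The data offer no measured reason for the step.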